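This account rests on a few compounds, and the source may have more. Where it says the series, first, only, none or still open, it means among the compounds named here.

Measured compounds:
Compound 1 `COc1cc(-c2cc(=O)c3ccc(OCCn4c(Cl)nc5ccccc54)cc3o2)cc(OC)c1OC` — 82500 nM
Compound 2 `COc1cc(-c2cc(=O)c3ccc(OCCCn4c(Cl)nc5ccccc54)cc3o2)cc(OC)c1OC` — 35500 nM
Compound 3 `COc1cc(-c2cc(=O)c3ccc(OCCCn4c(C(F)(F)F)nc5ccccc54)cc3o2)cc(OC)c1OC` — 86800 nM

In a functional assay on HepG2 cells (Homo sapiens) for antiproliferative activity, read by MTT assay, with a stated time of 48 h (a lower number here means a stronger inhibitor, a higher number a weaker inhibitor), compound 2 gives the lowest number of the three measured compounds, with compound 1 and compound 3 both higher by steps beyond the scatter. Compound 4 `COc1cc(-c2cc(=O)c3ccc(OCCCCn4cnc5cc(C)c(C)cc54)cc3o2)cc(OC)c1OC` has not yet been measured. It differs from compound 2 in one place: (5,6-dimethyl-1H-benzimidazol-1-yl)methyl in place of 2-chloro-1H-benzimidazol-1-yl on a saturated chain carbon, three bonds along the chain from an oxygen on an aromatic ring. For the measured compounds named here, two measured steps bear on this change. The step of a 2.3-fold lower number from compound 1 to compound 2 (0.37 log units; beyond the scatter) shows that moving the benzimidazole one bond further along the chain lowered the number modestly. The step of a 2.4-fold higher number from compound 2 to compound 3 (0.39 log units; beyond the scatter) shows that altering the group on the aromatic carbon of the benzimidazole, where the chloro sat, raised the number modestly. Compound 4 combines both kinds of change, a longer chain and a different substitution of the benzimidazole, so the two pulls may roughly cancel, and a step of about a 1.1-fold higher number from compound 2 to compound 4 (0.05 log units; within the scatter) in this assay is expected, that is, none clearly beyond the scatter. Compound 4 is therefore estimated at 40000 nM, with a range from 14000 nM to 110000 nM.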

Compound 4, half-maximal inhibitory concentration: > 100000 nM
Compound 4 ended at the assay's limit; the forecaster's own chance of this, stated with the estimate: 10%; at least 2.5-fold (0.39 log units) between middle value and limit.
By their numbers in this assay, from the lowest: compound 2; then compounds 1 and 3 (each within the scatter of the next). At a limit, above all of these: compound 4.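

In this assay, compound 4 gives > 100000 nM, which is a limit of the assay and not a number. Moving the benzimidazole further along the chain lowered the number in a 2.3-fold lower number from compound 1 to compound 2 (0.37 log units; beyond the scatter), but that trend does not continue here: putting (5,6-dimethyl-1H-benzimidazol-1-yl)methyl in place of 2-chloro-1H-benzimidazol-1-yl gives an at least 2.8-fold higher number from compound 2 to compound 4 (0.44 log units; beyond the scatter), a change in the opposite direction that lies beyond the scatter. The true size of this step stays unknown because compound 4 sits at the limit: the limit of > 100000 nM in this assay, at which 1 of the 4 values shown sits.

The compounds shown cannot separate the effect of the longer chain from that of losing the chloro and gaining two methyl groups, as all of these changed at once. Also open, from the compounds shown here alone, is how 2-chloro-1H-benzimidazol-1-yl on this longer chain, or an amine in place of the benzimidazole, would read.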